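Compound 4: an estimate from a sparse series

The compounds below may be only part of what the source reports. "The series", "measured", "known", "first", "only" and "open" are said of these compounds alone.

In a functional assay on MDA-MB-231 cells (Homo sapiens) for antiproliferative activity, with a stated time of 72 h (on this read-out higher numbers stand for an effect only at larger amounts of compound and lower numbers for an effect already at smaller amounts), compound 3 (`CN(C)C(=O)c1ccc(N(Cc2ccc(C3CCCCC3)cn2)C(=O)[C@H]2CCN2S(=O)(=O)c2c(F)c(F)c(F)c(F)c2F)cc1O`) offers no number, its result being "not determined" (no result reported). Compound 1 (`O=C(O)c1ccc(N(Cc2ccc(C3CCCCC3)cc2)C(=O)[C@H]2CCN2S(=O)(=O)c2c(F)c(F)c(F)c(F)c2F)c(F)c1`) reads > 10000 nM, which is a limit of the assay and not a number. Compound 2 (`O=C(NO)c1ccc(N(Cc2ccc(C3CCCCC3)cc2)C(=O)[C@H]2CCN2S(=O)(=O)c2c(F)c(F)c(F)c(F)c2F)cc1`) gives 5000 nM. Compound 4 (`O=C([C@H]1CCN1S(=O)(=O)c1c(F)c(F)c(F)c(F)c1F)N(Cc1ccc(C2CCCCC2)cn1)c1ccc2nn[nH]c2c1`) comes from compound 3 by one change: a group of 9 heavy atoms (6 carbon, 3 nitrogen; one five-membered aromatic ring with 3 hetero atoms, one six-membered aromatic ring of carbon only) in place of a group of 12 heavy atoms (9 carbon, 1 nitrogen, 2 oxygen; one six-membered aromatic ring of carbon only), on an amide-type nitrogen. For the measured compounds named here, the only measured step, an at least 2.0-fold lower number from compound 1 to compound 2 (0.30 log units; that floor lies within the scatter), also swaps a group on an amide-type nitrogen, but it involves different groups, and its floor lies within the scatter. With no number for compound 3, no size or direction of step can be expected, so the estimate leans on compound 2 at 5000 nM. Compound 4 is expected at about 5000 nM, with an estimated range of 1500 nM to 10000 nM.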

Compound 4, half-maximal effective concentration: 6600 nM
Beside the measured number, compound 4's estimate is 1.3-fold (0.12 log units) below it, and the stated range covers the measured number.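

For the compounds shown here, compound 3 has no reported result, so no step from compound 3 to compound 4 can be read. Whether the group entering in compound 4 shifts the effect in this assay stays open, and nothing shown bears on its result.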